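A few compounds are considered here, and "the series" means these few. Any claim that something is new, unique, unknown or untested is made for them only; others in the source may bear on it.

In a functional assay on A2780 cells (Homo sapiens) for inhibition, read by sulforhodamine B assay, with a stated time of 72 h (on this read-out higher numbers stand for weaker inhibition and lower numbers for stronger inhibition), three amides that differ only in the group on the carbonyl carbon have been measured. Compound 1 `O=C(NCc1ccc(S(=O)(=O)N2CCCCC2)cc1)c1cc2ccncc2[nH]1` gives 1700 nM. Compound 2 `O=C(NCc1ccc(S(=O)(=O)N2CCCCC2)cc1)c1cc2cccnc2s1` reaches only a limit of the assay, > 10000 nM. Compound 3 `O=C(NCc1ccc(S(=O)(=O)N2CCCCC2)cc1)c1ccn2cncc2c1` also stands at a limit, > 10000 nM, so it has no number of its own. This is the limit of > 10000 nM in this assay, at which 2 of the 3 values shown sit.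

Compound 4 `O=C(NCc1ccc(S(=O)(=O)N2CCCCC2)cc1)c1cc2ccncc2o1` changes the same place: a group of 9 heavy atoms (7 carbon, 1 nitrogen, 1 oxygen; one five-membered aromatic ring with 1 hetero atom, one six-membered aromatic ring with 1 hetero atom) in place of a group of 9 heavy atoms (7 carbon, 2 nitrogen; one five-membered aromatic ring with 2 hetero atoms, one six-membered aromatic ring with 1 hetero atom), on a carbonyl carbon. Among the measured compounds shown here, the steps that bear on this change are the other swaps on that carbonyl carbon. These are an at least 5.8-fold higher number from compound 1 to compound 3 (0.76 log units; beyond the scatter) and an at least 5.8-fold higher number from compound 1 to compound 2 (0.76 log units; beyond the scatter), both beyond the scatter, and their true sizes are hidden by the limit. The step that the two limits leave unreadable from compound 2 to compound 3 gives no guidance. The entering group has one five-membered aromatic ring with 1 hetero atom, but the groups of compound 1 and compound 2 share that count and still part by the step above, so the count settles little.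

For the measured compounds named here, the only number to lean on is that of compound 1, at 1700 nM. A reading that stays at the limit remains possible. The expected change is modest, toward stronger inhibition, and is estimated as an at least 4.0-fold lower number from compound 3 to compound 4 (0.60 log units; beyond the scatter). For compound 4 the estimated value is 2500 nM, with an expected range from 500 nM to 10000 nM.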

Compound 4, half-maximal inhibitory concentration: 29 nM
Compound 4: middle estimate off by 86-fold (1.94 log units), on the high side; measured number outside the range, below it.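

In this assay, among the compounds shown here, the group on the carbonyl carbon proves able to move the read-out much further than the earlier compounds showed, and the one fully readable step at this place is a 59-fold lower number from compound 1 to compound 4 (1.77 log units; beyond the scatter). Compounds 2 and 3 stand at a limit of the assay, so the steps of an at least 340-fold lower number from compound 2 to compound 4 (2.53 log units; beyond the scatter) and an at least 340-fold lower number from compound 3 to compound 4 (2.53 log units; beyond the scatter) give only minimum sizes, and their true sizes stay hidden: the limit of > 10000 nM in this assay, at which 2 of the 4 values shown sit. The entering group has the same ring and hetero atom counts as the groups of compound 1 and compound 2, and the same donor and acceptor counts as the group of compound 3, so none of these counts separates compound 4 from the others.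

On these data alone, it remains open whether a fluorine atom or an amine on the entering group would keep the strong inhibition of compound 4 or lose it. The rest of the molecule is the same in all four compounds, so they say nothing about how much that shared part contributes to the value of compound 4.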